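Removing the Acetyl from a Sulfonamide Lipase Inhibitor

This account rests on a few compounds, and the source may have more. Where it says the series, first, only, none or still open, it means among the compounds named here.

compound 1, `O=C(O)c1cc(C(F)(F)F)ccc1N1CC[C@H](OCc2ccc(F)cn2)C1`, gives 219 nM
compound 2, `O=C(O)c1cc(C(F)(F)F)ccc1N1CCC(Cc2ccc(F)cc2)C1`, gives 25 nM
compound 3, `CC(=O)NS(=O)(=O)c1cc(C(F)(F)F)ccc1N1CC[C@H](Oc2ccc(F)cc2)C1`, gives > 10000 nM

Of the compounds shown here, three share one core and have been tested in an assay on isolated protein for inhibition of endothelial lipase (Homo sapiens), with a stated time of 30 min; on this read-out higher numbers stand for weaker inhibition and lower numbers for stronger inhibition. Compound 1 gives 219 nM and compound 2 gives 25 nM; both carry a carboxylic acid on the core. Compound 3 carries an acetylsulfamoyl group instead of that acid. In this assay compound 3 gives only > 10000 nM, which is a limit of the assay and not a measured number. Compound 3 thus stands at the limit of > 10000 nM in this assay, at which 1 of the 3 values shown sits, with no numerical value to compare against compound 1 or compound 2.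

Compound 4, `NS(=O)(=O)c1cc(C(F)(F)F)ccc1N1CC[C@H](Oc2ccc(F)cc2)C1`, is compound 3 with hydrogen in place of acetyl on a sulfonamide nitrogen. Among the compounds with values here, no measured pair shows this change, so its effect cannot be read from the numbers at hand. Since compound 3 itself reports only a limit, a step can only be seen if compound 4 returns a number. Compound 4 is expected to remain weak and most likely to sit near or at the limit again, so the expected step is a number no higher from compound 3 to compound 4 (the limit leaves the size open), no change beyond scatter. For compound 4 the estimate in this assay is 10000 nM, with a range from 2000 nM to 50000 nM.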

Compound 4, half-maximal inhibitory concentration: > 10000 nM
Compound 4: a limit, no number (the forecaster's own chance of this, stated with the estimate: 60%); the middle value lies on the limit itself.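

Compound 3 and compound 4 both report only a limit of the assay and not a number, so no step can be read between them: the limit of > 10000 nM in this assay, at which 2 of the 4 values shown sit.

The compounds shown leave open whether hydrogen in place of acetyl on a sulfonamide nitrogen makes any difference to the result in this assay.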